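From chloro to methyl on an aromatic ring

The source may report more compounds than this note shows. Statements on the series, on what has been measured and on what is new or still open speak of the compounds shown alone.

In a functional assay on A549 cells (Homo sapiens) for antiproliferative activity, read by MTT assay, with a stated time of 72 h (on this read-out higher numbers stand for weaker inhibition and lower numbers for stronger inhibition), compound 1 `COc1ccc(OC)c(-c2c(C(=O)c3cc(OC)c(OC)c(OC)c3)sc3ccccc23)c1` gives > 10000 nM, which is a limit of the assay and not a number. Among the measured compounds shown here, compound 2 `COc1cc(C(=O)c2sc3ccccc3c2Nc2ccc(Cl)cc2)cc(OC)c1OC` gives 3100 nM, the only true number so far. For the measured compounds named here, putting (4-chlorophenyl)amino in place of 2,5-dimethoxyphenyl on an aromatic carbon gives an at least 3.2-fold lower number from compound 1 to compound 2 (0.50 log units; beyond the scatter), and this is the only measured step.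

Compound 3 `COc1cc(C(=O)c2sc3ccccc3c2Nc2ccc(C)cc2)cc(OC)c1OC` follows from compound 2 with methyl in place of chloro on an aromatic carbon, para to a large group (methyl in place of chloro on an aromatic carbon). The measured step of an at least 3.2-fold lower number from compound 1 to compound 2 (0.50 log units; beyond the scatter) replaces the whole group, so it bears on this smaller change only loosely. Going by the values given here, it sets no size for the step ahead. In this assay, the expected change is a 1.6-fold lower number from compound 2 to compound 3 (0.19 log units; within the scatter), a small lean to a lower number that is not expected to stand clearly beyond the scatter. For compound 3, the estimated value is 2000 nM, with an expected range of 450 nM to 8000 nM.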

Compound 3, half-maximal inhibitory concentration: 2600 nM
Compound 3: the middle estimate sits 1.3-fold (0.11 log units) below what was measured; the measured number falls inside the stated range.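

In this assay, the step at this place on the ring, para to a large group, is a 1.2-fold lower number from compound 2 to compound 3 (0.08 log units; within the scatter), so methyl and chloro cannot be told apart here. The earlier compounds shown here showed only the exchange of a whole group, whereas (4-methylphenyl)amino now gives a second such exchange, with an at least 3.8-fold lower number from compound 1 to compound 3 (0.58 log units; beyond the scatter). Compound 1 stands at a limit, so the full size of that step stays unknown: the limit of > 10000 nM in this assay, at which 1 of the 3 values shown sits.

The compounds shown leave open whether another group at this place on the ring, such as an amine, a carboxylic acid or a longer chain, would move the number beyond the scatter. Also open, from the compounds shown here alone, is how much of the difference from compound 1 belongs to the amino link and how much to the ring it carries, as both steps from compound 1 change the two together.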